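Methyl in place of methoxy on an aromatic carbon

This account rests on a few compounds, and the source may have more. Where it says the series, first, only, none or still open, it means among the compounds named here.

In a functional assay on HeLa cells (Homo sapiens) for antiproliferative activity, read by MTT assay, with a stated time of 48 h (on this read-out lower numbers stand for stronger inhibition and higher numbers for weaker inhibition), compound 1 `O=[N+]([O-])c1cccc(-c2nn(-c3ccccc3)cc2C(Nc2nc3ccccc3s2)c2c(O)ccc3ccccc23)c1` gives 8220 nM, compound 2 `Oc1ccc2ccccc2c1C(Nc1nc2ccccc2s1)c1cn(-c2ccccc2)nc1-c1ccccc1` gives 17300 nM and compound 3 `COc1cccc(-c2nn(-c3ccccc3)cc2C(Nc2nc3ccccc3s2)c2c(O)ccc3ccccc23)c1` gives 14900 nM. The number for compound 3 cannot be separated from either of the others. Methoxy in place of hydrogen gave a 1.2-fold lower number from compound 2 to compound 3 (0.06 log units; within the scatter), and methoxy in place of nitro gave a 1.8-fold higher number from compound 1 to compound 3 (0.26 log units; within the scatter). Only hydrogen in place of nitro, a 2.1-fold higher number from compound 1 to compound 2 (0.32 log units; beyond the scatter), passed the scatter. Compound 4 `Cc1cccc(-c2nn(-c3ccccc3)cc2C(Nc2nc3ccccc3s2)c2c(O)ccc3ccccc23)c1` carries methyl in place of methoxy on an aromatic carbon. With steps this small at that group, no change beyond the scatter is expected in this assay. The expected step is a 1.1-fold lower number from compound 3 to compound 4 (0.03 log units; within the scatter). Compound 4 is estimated at 14000 nM, with an expected range of 8000 nM to 24000 nM.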

Compound 4, half-maximal inhibitory concentration: 7020 nM
Beside the measured number, compound 4's estimate is 2.0-fold (0.30 log units) above it; the whole stated range lies above it.
By their numbers in this assay, from the lowest: compounds 4, 1, 3 and 2 (each within the scatter of the next, the first and the last beyond it).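

In this assay this position proved able to move the number: methyl in place of methoxy gave a 2.1-fold lower number from compound 3 to compound 4 (0.33 log units; beyond the scatter) and methyl in place of hydrogen gave a 2.5-fold lower number from compound 2 to compound 4 (0.39 log units; beyond the scatter), whereas methoxy in place of hydrogen had stayed within the scatter. Methyl in place of nitro gave a 1.2-fold lower number from compound 1 to compound 4 (0.07 log units; within the scatter), so these two groups cannot be told apart here. Nothing measured here bears on the cause of these steps. Going by these compounds, whether an amine, a carboxylic acid or a longer chain such as ethyl in place of the methyl would keep the number of compound 4 stays open.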